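The compounds below may be only part of what the source reports. "The series", "measured", "known", "first", "only" and "open" are said of these compounds alone.

Measured in a functional assay on PANC-1 cells (Homo sapiens) for inhibition, read by MTT assay, with a stated time of 24 h, tested at 10 uM; on this read-out higher numbers stand for more inhibition at the one concentration tested (going by the name of the read-out) and lower numbers for less inhibition:
- compound 1 `CC(C)=CCOc1cc(=O)n(CCCO)c2c1CC(CC=C(C)C)C(C)(C)C2` gives 7.5%
- compound 2 `CC(C)=CCC/C(C)=C/COc1cc(=O)n(CCCO)c2c1CC(CC=C(C)C)C(C)(C)C2` gives 18.4%
- compound 3 `COc1ccc(C(=O)NCCCOc2cc(=O)n(CCCO)c3c2CC(CC=C(C)C)C(C)(C)C3)cc1` gives 2.5%

In this assay compound 3 sits within the scatter of compound 1 and beyond it from compound 2, so the numbers of compound 3 and compound 1 cannot be told apart, while compound 2 stands apart from both.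

Compound 4 `COc1ccc(OCCCOc2cc(=O)n(CCCO)c3c2CC(CC=C(C)C)C(C)(C)C3)cc1` differs from compound 3 in one place: 4-methoxyphenoxy in place of ((4-methoxyphenyl)carbonyl)amino on a saturated chain carbon, three bonds along the chain from an oxygen on an aromatic ring. Within the data shown here, the only measured step, a number 10.9 percentage points higher from compound 1 to compound 2 (beyond the scatter), concerns a different position on a different chain and does not bear on an exchange of this kind; no measured pair shows the amide-to-ether change itself. With nothing in hand to point either way, the expectation for compound 4 is a step of no clear size, a number 2.5 percentage points higher from compound 3 to compound 4 (within the scatter), with the estimate for compound 4 in this assay set near the number of compound 3 at 5%, expected between -5% and 15%.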

Compound 4, a percentage reported as inhibition, at one concentration (the size of the read-out at that concentration, not a potency): 4.1%
Compound 4: the middle estimate sits 0.9 percentage points above what was measured; the range from low to high includes it.
By their numbers in this assay, from the lowest: compounds 3, 4 and 1 (each within the scatter of the next); then compound 2.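

In this assay, 4-methoxyphenoxy in place of ((4-methoxyphenyl)carbonyl)amino gives a number 1.6 percentage points higher from compound 3 to compound 4 (within the scatter) and so, for this pair, losing the amide hydrogen leaves the read-out unchanged within the scatter. With 2-(4-methoxyphenoxy)ethyl on the saturated chain carbon bound to an oxygen on an aromatic ring, the replacement of 2-methylprop-1-en-1-yl gives a number 3.4 percentage points lower from compound 1 to compound 4 (within the scatter) while the replacement of 2,6-dimethylhepta-1,5-dien-1-yl gives a number 14.3 percentage points lower from compound 2 to compound 4 (beyond the scatter) and leaves compound 2 apart from compound 4. No supporting data bear on the reason for any of these steps.

From the compounds shown here alone, whether a terminal amine or carboxylic acid on this chain would lift the number beyond the scatter remains open. Also open, going by these compounds, is whether the higher number of compound 2 carries over to a still longer unsaturated chain on the same oxygen.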